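Trimming Isobutyl to Isopropyl at an Assay Limit

This account rests on a few compounds, and the source may have more. Where it says the series, first, only, none or still open, it means among the compounds named here.

Of the compounds shown here, three sharing one core have been tested in a toxicity assay on Vero cells (Chlorocebus sabaeus) for cytotoxicity, read by MTT assay, with a stated time of 72 h; a higher number here means a weaker inhibitor, a lower number a stronger inhibitor. Compound 1 `CC(C)(C)c1nc2ccccc2n1C(=O)c1cccc2ccccc12` gives > 10000 nM, which is a limit and not a number. Compound 2 `O=C(c1cccc2ccccc12)n1c(C2CCC2)nc2ccccc21` gives > 10000 nM, again a limit. Compound 3 `COc1ccc(C(=O)n2c(CC(C)C)nc3ccccc32)cc1` gives > 10000 nM, also a limit. The series therefore offers only (the limit of > 10000 nM in this assay, at which 3 of the 3 values shown sit).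

Compound 4 `COc1ccc(C(=O)n2c(C(C)C)nc3ccccc32)cc1` has not yet been measured. It differs from compound 3 in one place, with isopropyl in place of isobutyl on an aromatic carbon.

The nearest measured change is also a swap of one carbon group on an aromatic carbon, with cyclobutyl in place of tert-butyl: a step that the two limits leave unreadable from compound 1 to compound 2. Its size cannot be read, so it gives no guide to how large the new step should be.

Because compound 3 gives > 10000 nM and that is only a limit, no step beyond the usual scatter is expected in this assay, and no direction can be named. The expected step is a step that the limit leaves unreadable from compound 3 to compound 4. For compound 4 the estimate is 20000 nM, with an expected range from 8000 nM to 50000 nM. A reading reported only as a limit is the likeliest outcome.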

Compound 4, half-maximal inhibitory concentration: > 10000 nM
Compound 4: a limit, no number; the forecaster's own chance of this, stated with the estimate: 85%; the middle value is on the limit's open side.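

Within the data shown here, compound 3 and compound 4 both end at a limit in this assay, so swapping isobutyl for isopropyl gives no step whose size can be read. The compounds shown leave open how toxic any of them actually is to these cells, and whether they differ at all, because every reading stops at the same point: the limit of > 10000 nM in this assay, at which 4 of the 4 values shown sit.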